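Sulfonyl substituent exchange at the distal sulfonamide

This account rests on a few compounds, and the source may have more. Where it says the series, first, only, none or still open, it means among the compounds named here.

Compound 3 `O=C([C@@H]1CCCN(S(=O)(=O)c2ccc(S(=O)(=O)N3CC[C@H](O)C3)cc2)C1)N1CCC(F)(F)CC1` gives 580 nM in a functional assay on BXPC-3 cells (Homo sapiens) for inhibition, read by MTT assay, with a stated time of 7 days; on this read-out lower numbers stand for stronger inhibition and higher numbers for weaker inhibition. Among the three measured compounds it holds the highest number; compound 1 `O=C([C@@H]1CCCN(S(=O)(=O)c2ccc(S(=O)(=O)N3CC[C@@H](O)C3)cc2)C1)N1CCC(F)(F)CC1` gives 330 nM and compound 2 `O=C([C@@H]1CCCN(S(=O)(=O)c2ccc(S(=O)(=O)C3COC3)cc2)C1)N1CCC(F)(F)CC1` gives 361 nM in this assay, and the gaps a 1.8-fold higher number from compound 1 to compound 3 (0.24 log units; within the scatter) and a 1.6-fold higher number from compound 2 to compound 3 (0.21 log units; within the scatter) both lie within the scatter, so no order among the three can be read. Compound 1 and compound 3 are the same apart from configuration (the fact that compounds 1 and 3 differ only in the configuration as drawn).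

Compound 4 `CC(C)NS(=O)(=O)c1ccc(S(=O)(=O)N2CCC[C@@H](C(=O)N3CCC(F)(F)CC3)C2)cc1` arises from compound 3 by isopropylamino in place of 3-hydroxypyrrolidin-1-yl on a sulfonyl sulfur. The measured steps that touch the same sulfonyl sulfur are a 1.1-fold higher number from compound 1 to compound 2 (0.04 log units; within the scatter) and a 1.6-fold higher number from compound 2 to compound 3 (0.21 log units; within the scatter): exchanging the hydroxypyrrolidinyl for the oxetanyl, or back, moved the read-out by no more than the scatter. The step into isopropylamino removes the ring and the hydroxyl, a change not covered by any measured pair, so the expectation rests only on the observation that replacement at this sulfonyl sulfur has so far produced no shift beyond the scatter. For compound 4 a step of a 1.3-fold lower number from compound 3 to compound 4 (0.11 log units; within the scatter) is therefore expected, in neither direction beyond the scatter. Compound 4 is estimated at 450 nM, with a range from 200 nM to 1200 nM.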

Compound 4, half-maximal inhibitory concentration: 470 nM
For compound 4 the middle estimate is 1.0-fold (0.02 log units) below the measured one; the range from low to high includes it.
By their numbers in this assay, from the lowest: compounds 1, 2, 4 and 3 (each within the scatter of the next).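

In this assay, isopropylamino in place of 3-hydroxypyrrolidin-1-yl on a sulfonyl sulfur gives a 1.2-fold lower number from compound 3 to compound 4 (0.09 log units; within the scatter) and a 1.4-fold higher number from compound 1 to compound 4 (0.15 log units; within the scatter), so the exchange that removes the ring, the hydroxyl and the defined stereocentre of the leaving group together produces no shift beyond the scatter. Both steps lead to the same compound and remove the same group in its two drawn forms, which lets the exchange be read from either configuration, and neither reading departs from the scatter; the comparison rests on one fact: the fact that compounds 1 and 3 differ only in the configuration as drawn. Against the oxetan-3-yl group, the same entering group gives a 1.3-fold higher number from compound 2 to compound 4 (0.11 log units; within the scatter), so the three substituent types at this sulfur, with a ring or without one, still cannot be put in any order.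

As far as these compounds go, whether a primary amine, a carboxylic acid or a longer alkyl chain on this sulfonyl sulfur would move the read-out beyond the scatter stays open. From the compounds shown here alone, what a change elsewhere on the shared core would do to the read-out also stays open.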